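The compounds below may be only part of what the source reports. "The series", "measured", "known", "first", "only" and "open" are said of these compounds alone.

Compound 2 `CC1=C(C(C)C(=O)NCCN2CCNCC2)c2cc(F)ccc2/C1=C\c1ccc([S+](C)[O-])cc1` stands at the edge of what a functional assay on MDA-MB-231 cells (Homo sapiens) for inhibition, read by CellTiter-Glo, with a stated time of 96 h (a lower number here means that less compound is tolerated, a higher number that more compound is tolerated), can report: in this assay compound 2 gives only > 50000 nM, a limit rather than a number. Compound 1 `CC1=C(C(C)C(=O)N(C)CCN(C)C)c2cc(F)ccc2/C1=C\c1ccc([S+](C)[O-])cc1` likewise gives > 50000 nM in this assay, again a limit. The step that the two limits leave unreadable from compound 1 to compound 2 is therefore unreadable, as the limit of > 50000 nM in this assay, at which 2 of the 2 values shown sit, shows. Compound 3 `CC1=C(C(C)C(=O)N2CCN(c3ccncc3)CC2)c2cc(F)ccc2/C1=C\c1ccc([S+](C)[O-])cc1` carries 4-(pyridin-4-yl)piperazin-1-yl in place of (2-(piperazin-1-yl)ethyl)amino on a carbonyl carbon. With no readable step to build on, no direction beyond the scatter is expected for compound 3, whose value is estimated at 50000 nM with a range of 15000 nM to 150000 nM, implying an expected step of a number no higher from compound 2 to compound 3 (the limit leaves the size open).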

Compound 3, half-maximal cytotoxic concentration: 19600 nM
The estimate for compound 3 lay 2.6-fold (0.41 log units) above the measured number, within the range that was stated.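

In this assay, the group on the carbonyl carbon can now be seen to move the read-out: 4-(pyridin-4-yl)piperazin-1-yl gives an at least 2.5-fold lower number from compound 2 to compound 3 (0.40 log units; beyond the scatter) and an at least 2.5-fold lower number from compound 1 to compound 3 (0.40 log units; beyond the scatter). Among the compounds shown here, compound 3 is the first of the three to give a number rather than a limit. Both steps give only a minimum size, since the other two compounds sit at a limit: the limit of > 50000 nM in this assay, at which 2 of the 3 values shown sit.

From the compounds shown here alone, it remains open how much of the step belongs to the pyridin-4-yl ring. Whether a phenyl group in its place, or a morpholine on the carbonyl carbon, would also give a number in this assay is not shown.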